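This account rests on a few compounds, and the source may have more. Where it says the series, first, only, none or still open, it means among the compounds named here.

Measured so far in a functional assay (Homo sapiens) for inhibition; on this read-out lower numbers stand for stronger inhibition and higher numbers for weaker inhibition:

Compound 1 `CC(O)n1cnc2c(N)nc(I)nc21` — > 500000 nM, a limit of the assay.
Compound 2 `Nc1nc(I)nc2c1ncn2OCCO` — > 500000 nM, a limit of the assay.

Compound 2 thus stands only at a limit in this assay, with no number beneath it. The step that the two limits leave unreadable from compound 1 to compound 2 cannot be read, because the limit of > 500000 nM in this assay, at which 2 of the 2 values shown sit, holds both values. Compound 3 `COc1nc(I)nc2c1ncn2OCCO` carries methoxy in place of amino on an aromatic carbon, methoxy in place of amino on an aromatic carbon. Going by the values given here, no measured step bears on this change, and the step from compound 2 is expected to be a step that the limit leaves unreadable from compound 2 to compound 3, most likely again unreadable against the limit. Compound 3 is therefore estimated at 800000 nM, ranging from 100000 nM to 5000000 nM.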

Compound 3, half-maximal inhibitory concentration: > 500000 nM
Compound 3 ended at the assay's limit; the forecaster's own chance of this, stated with the estimate: 85%; the middle value does not contradict the limit.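

The step between compound 2 and compound 3 cannot be read, since both values are limits and not numbers: the limit of > 500000 nM in this assay, at which 3 of the 3 values shown sit.

The compounds shown leave open how strongly compound 1, compound 2 or compound 3 inhibits, and whether methoxy in place of amino changes inhibition at all.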